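The source may report more compounds than this note shows. Statements on the series, on what has been measured and on what is new or still open speak of the compounds shown alone.

Among the compounds with values here, compound 2 `C/C(=N\Nc1ncc(Cl)c(Nc2cccc(NC(=O)/C=C/CN(C)C)c2)n1)c1ccc(F)cc1F` gives 3460 nM in an ADME assay on HT-29 cells (Homo sapiens) for inhibition, read by MTT assay, with a stated time of 72 h (a higher number here means a weaker inhibitor, a lower number a stronger inhibitor), the lowest of the two numbers measured so far. Compound 1 `C=CC(=O)Nc1cccc(Nc2nc(N/N=C(\C)c3cccc(OC)c3)ncc2Cl)c1`, which carries a different amide and a different aryl group, gives 8990 nM in this assay, a higher number that lies beyond the usual scatter. Compound 3 `COc1cccc(/C(C)=N/Nc2ncc(Cl)c(Nc3cccc(NC(=O)/C=C/CN(C)C)c3)n2)c1` has not yet been measured; it differs from compound 2 by 3-methoxyphenyl in place of 2,4-difluorophenyl on a carbon with a double bond to nitrogen. Since compound 1, which also bears the 3-methoxyphenyl group, gives 8990 nM, a modest rise in the number is expected, so that compound 3 is estimated at 6000 nM, between 2500 nM and 15000 nM, a step of a 1.7-fold higher number from compound 2 to compound 3 (0.24 log units; within the scatter) that is expected.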

Compound 3, half-maximal inhibitory concentration: 3870 nM
Compound 3: the middle estimate sits 1.6-fold (0.19 log units) above what was measured, within the range that was stated.
By their numbers in this assay, from the lowest: compounds 2 and 3 (each within the scatter of the next); then compound 1.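

In this assay, 3-methoxyphenyl in place of 2,4-difluorophenyl on the carbon with a double bond to nitrogen gives only a 1.1-fold higher number from compound 2 to compound 3 (0.05 log units; within the scatter), so these two groups cannot be told apart at this place. On the carbonyl carbon, 3-(dimethylamino)prop-1-en-1-yl in place of vinyl gives a 2.3-fold lower number from compound 1 to compound 3 (0.37 log units; beyond the scatter), which shows that the number responds to a change at that place. No measurement at hand explains either result. From the compounds shown here alone, it remains open whether an unsubstituted phenyl or a pyridine ring on the carbon with a double bond to nitrogen, or a morpholine in place of the dimethylamino group on the chain, would shift the number.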